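Replacing the Ring Substituent of Compound 2

The source may hold more compounds than are shown below. What is called first, only, known or untested is meant among the compounds shown, and "the series" means these compounds.

Measured in an ADME assay on microsomes from liver (Homo sapiens) for metabolic stability, read by LC-MS, using NADPH, with stated times of 5 min and 30 min, tested at 1 uM; on this read-out lower numbers stand for slow clearance and higher numbers for fast clearance:
- compound 1 `CC(=O)N1CCC(c2cnc(NCc3c(F)ccc4c3CCO4)c3cn[nH]c(=O)c23)CC1`: 207 mL.min-1.g-1
- compound 2 `Cc1nc(CN(C)C)ccc1-c1cnc(NCc2c(F)ccc3c2CCO3)c2cn[nH]c(=O)c12`: 13 mL.min-1.g-1

Of these two compounds, compound 2 has the lower number, at 13 mL.min-1.g-1, and so is cleared more slowly. The next compound to be tested is compound 3 `Cc1cc(-c2cnc(NCc3c(F)ccc4c3CCO4)c3cn[nH]c(=O)c23)n(C)n1`. It shares the core of compound 2, but 1,3-dimethyl-1H-pyrazol-5-yl replaces 6-((dimethylamino)methyl)-2-methylpyridin-3-yl on an aromatic carbon: 1,3-dimethyl-1H-pyrazol-5-yl in place of 6-((dimethylamino)methyl)-2-methylpyridin-3-yl on an aromatic carbon.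

For the measured compounds named here, only one measured step bears on this change: a 16-fold lower number from compound 1 to compound 2 (1.20 log units; beyond the scatter). It involves the same aromatic carbon and shows that the group placed there can shift the number by a large amount. That step does not test the incoming group, so it offers only indirect guidance. With compound 2 at the low end and compound 1 at 207 mL.min-1.g-1, a value between the two seems the most reasonable expectation. The expected change is a 3.1-fold higher number from compound 2 to compound 3 (0.49 log units; beyond the scatter), a moderate rise. For compound 3, the estimated value in this assay is 40 mL.min-1.g-1, with an expected range of 14 mL.min-1.g-1 to 120 mL.min-1.g-1.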

Compound 3, intrinsic clearance in microsomes: 24 mL.min-1.g-1
Estimate against measurement, compound 3: 1.7-fold (0.22 log units) above, within the range that was stated.
By their numbers in this assay, from the lowest: compounds 2 and 3 (each within the scatter of the next); then compound 1.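

In this assay, swapping the 6-((dimethylamino)methyl)-2-methylpyridin-3-yl group for 1,3-dimethyl-1H-pyrazol-5-yl gives a 1.8-fold higher number from compound 2 to compound 3 (0.27 log units; within the scatter), so the read-out does not separate these two groups, even though the six-membered aromatic ring with 11 heavy atoms gives way to a five-membered aromatic ring with 7. Set against the 1-acetylpiperidin-4-yl group, the same pyrazole gives an 8.6-fold lower number from compound 1 to compound 3 (0.94 log units; beyond the scatter), which shows that the low clearance seen at this aromatic carbon is not unique to the pyridine-bearing compound 2 and also holds for a smaller aromatic group that lacks the dimethylamino arm. Nothing measured here accounts for these numbers.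

For the compounds shown here, with only three compounds, it remains open whether the aromatic ring itself matters or whether the difference lies in some other feature of the acetylated piperidine, a question that a plain phenyl ring or a piperidin-4-yl group with a free amine could help to address. On these data alone, it is also open how far the pyrazole tolerates change, for example a dimethylaminomethyl group or a carboxylic acid in place of one of its methyl groups.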